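The source may report more compounds than this note shows. Statements on the series, on what has been measured and on what is new or still open speak of the compounds shown alone.

Three compounds built on one shared core were tested in a functional assay on HBL-100 cells (Homo sapiens) for inhibition, read by sulforhodamine B assay, with a stated time of 48 h; a lower number here means a stronger inhibitor of growth, a higher number a weaker inhibitor of growth. Compound 1 `COC(=O)[C@@]1(C)CCC=C2[C@@H]1CC[C@@H](C)[C@]2(C)Cc1c[nH]c2ccc(C)cc12` gives 18000 nM. Compound 2 `COC(=O)[C@@]1(C)CCC=C2[C@@H]1CC[C@@H](C)[C@]2(C)Cc1c[nH]c2ccc(Br)cc12` gives 16000 nM. Compound 3 `COC(=O)[C@@]1(C)CCC=C2[C@@H]1CC[C@@H](C)[C@]2(C)Cc1c[nH]c2ccc(F)cc12` gives 4800 nM, the lowest of the three: there is a 3.8-fold lower number from compound 1 to compound 3 (0.57 log units; beyond the scatter) and a 3.3-fold lower number from compound 2 to compound 3 (0.52 log units; beyond the scatter), both beyond the scatter, while a 1.1-fold lower number from compound 1 to compound 2 (0.05 log units; within the scatter). Compound 4 `COC(=O)[C@@]1(C)CCC=C2[C@@H]1CC[C@@H](C)[C@]2(C)Cc1c[nH]c2ccc(C(F)(F)F)cc12` differs from compound 3 by trifluoromethyl in place of fluoro on an aromatic carbon. Within the data shown here, the two steps that bear on this change both show that fluoro gave a lower number than methyl or bromo, so exchanging fluoro for trifluoromethyl is expected to raise the number again, though no tested compound carries that group. For compound 4 the expected step is a 2.5-fold higher number from compound 3 to compound 4 (0.40 log units; beyond the scatter). Compound 4 is therefore estimated at 12000 nM, with a range from 5000 nM to 30000 nM.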

Compound 4, concentration for 50% growth inhibition: 15000 nM
For compound 4 the middle estimate is 1.3-fold (0.10 log units) below the measured one, within the range that was stated.
By their numbers in this assay, from the lowest: compound 3; then compounds 4, 2 and 1 (each within the scatter of the next).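

In this assay, trifluoromethyl does not keep the lower number seen with fluoro (a 3.1-fold higher number from compound 3 to compound 4 (0.49 log units; beyond the scatter)). Instead, it falls level with the other two groups, bromo (a 1.1-fold lower number from compound 2 to compound 4 (0.03 log units; within the scatter)) and methyl (a 1.2-fold lower number from compound 1 to compound 4 (0.08 log units; within the scatter)), so among these four groups at this position only fluoro stands apart. No measured evidence is available to explain this difference. Going by these compounds, how chloro, a methoxy group or an amine would behave at this position remains open, so it is unclear whether the lower number is unique to fluoro.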